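A few compounds are considered here, and "the series" means these few. Any claim that something is new, unique, unknown or untested is made for them only; others in the source may bear on it.

In a functional assay on RAW264.7 cells (Mus musculus) for inhibition, read by Griess assay, with stated times of 1 h and 24 h (on this read-out lower numbers stand for stronger inhibition and higher numbers for weaker inhibition), compound 1 (`C=CCOc1ccccc1C1CC(=O)c2ccccc2O1`) gives 37800 nM and compound 2 (`CCCCOc1ccccc1C1CC(=O)c2ccccc2O1`) gives 48700 nM as the only two measured points so far. Compound 2 therefore stands within the scatter of compound 1, and neither can be ranked above the other. Compound 3 (`O=C1CC(c2ccccc2O)Oc2ccccc21`) has not yet been measured in this assay. Its structural change from compound 2 is hydrogen in place of butyl on an oxygen on an aromatic ring with hydrogen in place of butyl on an oxygen on an aromatic ring, so butoxy becomes hydroxy. Going by the values given here, only one measured step bears on this: a 1.3-fold higher number from compound 1 to compound 2 (0.11 log units; within the scatter) stays within the scatter, but it exchanges one chain on that oxygen for another and does not remove the chain. Among the compounds with values here, no measured compound carries the free hydroxy, so the data give no firm direction and the range must stay wide. On that slender basis, no step beyond the scatter is expected. The estimated step is a 1.4-fold lower number from compound 2 to compound 3 (0.14 log units; within the scatter) in this reading. For compound 3 the estimated value is 35000 nM with an expected range of 12000 nM to 100000 nM in this assay.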

Compound 3, half-maximal inhibitory concentration: 71300 nM
Estimate against measurement, compound 3: 2.0-fold (0.31 log units) below; measured number inside the range.
By their numbers in this assay, from the lowest: compounds 1, 2 and 3 (each within the scatter of the next).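

In this assay the chain on the oxygen on the aromatic ring can be removed altogether, not merely exchanged: butoxy to hydroxy gives a 1.5-fold higher number from compound 2 to compound 3 (0.17 log units; within the scatter) and hydrogen in place of allyl gives a 1.9-fold higher number from compound 1 to compound 3 (0.28 log units; within the scatter) in the same place. The earlier pair compared only two chains, whereas these steps add the free hydroxy, and neither the butyl nor the allyl compound separates from it beyond the scatter, so on this read-out the three groups at this position cannot be ranked. No supporting data accompany this result that could account for the absence of a separation.

Open, from the compounds shown here alone, is whether any other group on this oxygen, such as a longer chain, a chain ending in an amine or one ending in a carboxylic acid, would give a step beyond the scatter. The compounds shown differ only at this one place, so the response of this assay to changes elsewhere on the shared core also remains open.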